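The source may report more compounds than this note shows. Statements on the series, on what has been measured and on what is new or still open speak of the compounds shown alone.

Within the data shown here, compound 1 `O=C(Nc1ccc(I)cc1)N[C@H]1CC[C@H](Oc2ccc(F)cc2)CC1` is one of two compounds measured in a functional assay on CRL2813 cells (Homo sapiens) for cytotoxicity, read by sulforhodamine B assay, with a stated time of 5 days; a higher number here means a weaker inhibitor, a lower number a stronger inhibitor. In this assay compound 1 gives 10200 nM, the larger of the two numbers shown, with the other number within the scatter of it. Compound 2 `O=C(Nc1cccc(Br)c1)N[C@H]1CC[C@H](Oc2ccc(F)cc2)CC1` carries 3-bromophenyl in place of 4-iodophenyl on an amide-type nitrogen, and in this assay compound 2 gives 6200 nM; the step of a 1.6-fold lower number from compound 1 to compound 2 (0.22 log units; within the scatter) lies within the scatter. Compound 3 `O=C(Nc1cccc(I)c1)N[C@H]1CC[C@H](Oc2ccc(F)cc2)CC1` has not been measured. It differs from compound 1 as follows: 3-iodophenyl in place of 4-iodophenyl on an amide-type nitrogen. Among the measured compounds shown here, the one measured step that bears on this change is the one in which 3-bromophenyl replaced 4-iodophenyl, and that step did not leave the scatter. On that basis the step of a 1.4-fold lower number from compound 1 to compound 3 (0.13 log units; within the scatter) is expected to stay within the scatter as well. Compound 3 is therefore estimated at 7500 nM in this assay, within a range from 3500 nM to 16000 nM.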

Compound 3, half-maximal inhibitory concentration: 5200 nM
For compound 3 the middle estimate is 1.4-fold (0.16 log units) above the measured one; the measured number falls inside the stated range.
By their numbers in this assay, from the lowest: compounds 3, 2 and 1 (each within the scatter of the next).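

Compound 3 isolates the move of the iodine: 3-iodophenyl and 4-iodophenyl carry the same atoms on the amide-type nitrogen. In this assay this move alone gives a step that remains within the scatter (a 2.0-fold lower number from compound 1 to compound 3 (0.29 log units; within the scatter)). Exchanging bromo for iodo on an aromatic carbon, with the rest of the structure unchanged, also remains within the scatter (a 1.2-fold lower number from compound 2 to compound 3 (0.08 log units; within the scatter)), so neither single change separates these compounds in this assay. No supporting measurement offers an explanation for these numbers.

The three compounds shown differ only in the halogen-bearing phenyl group, so they leave open whether any change there could move the number beyond the scatter. From the compounds shown here alone, an amine or a carboxylic acid in place of the iodo group would test this, while changes elsewhere on the shared core remain unexplored here.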